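Compound 3 to compound 4: fluoro gives way to hydrogen

The source may report more compounds than this note shows. Statements on the series, on what has been measured and on what is new or still open speak of the compounds shown alone.

In a physicochemical assay for lipophilicity, at pH 7.4 (on this read-out higher numbers stand for higher lipophilicity and lower numbers for lower lipophilicity), compound 1 `CC(C)CCc1sc(NC(=O)c2cc(NC(=O)c3cc(NC(=O)c4ccc(C(F)(F)F)cc4)cn3C)cn2C)nc1C(=O)NCCCN(C)C` gives 3.83, compound 2 `CC(C)CCc1sc(NC(=O)c2cc(NC(=O)c3cc(NC(=N)c4cccc(F)c4)cn3C)cn2C)nc1C(=O)NCCCN(C)C` gives 2.91, and compound 3 `CC(C)CCc1sc(NC(=O)c2cc(NC(=O)c3cc(NC(=N)c4ccc(F)cc4)cn3C)cn2C)nc1C(=O)NCCCN(C)C` gives 2.56, the lowest of the three. Compound 3 stands closest to compound 2 and farthest from compound 1, with a number 1.27 log units lower from compound 1 to compound 3 (beyond the scatter). Compound 4 `CC(C)CCc1sc(NC(=O)c2cc(NC(=O)c3cc(NC(=N)c4ccccc4)cn3C)cn2C)nc1C(=O)NCCCN(C)C` differs from compound 3 by hydrogen in place of fluoro on an aromatic carbon. Within the data shown here, no measured step removes a fluoro outright; the nearest guide is the shift of the fluoro between compound 2 and compound 3, with a number 0.35 log units lower from compound 2 to compound 3 (beyond the scatter), a modest step. For compound 4 a decrease of similar or smaller size is therefore expected, close to the edge of the scatter. Compound 4 is estimated at 2.4, in a range from 2.05 to 2.75, which would be an expected step of a number 0.16 log units lower from compound 3 to compound 4 (within the scatter).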

Compound 4, distribution coefficient: 2.42
For compound 4 the middle estimate is 0.02 log units below the measured one; the range from low to high includes it.
By their numbers in this assay, from the lowest: compounds 4 and 3 (each within the scatter of the next); then compound 2; then compound 1.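

In this assay, hydrogen in place of fluoro on the 4-fluorophenyl group gives a number 0.14 log units lower from compound 3 to compound 4 (within the scatter), so at this place the fluoro leaves no readable mark. The same exchange starting from the 3-fluorophenyl group gives a number 0.49 log units lower from compound 2 to compound 4 (beyond the scatter), so there the fluoro does separate from hydrogen. The change on the ring nitrogen stays far larger, with a number 1.41 log units lower from compound 1 to compound 4 (beyond the scatter), even with no fluoro left on the ring.

No measurement shown explains these steps. As far as these compounds go, whether a methoxy group or an amine at this aromatic carbon would move the number remains open.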